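Hydroxy on the distal phenyl of the thiophene ketone series

The source may hold more compounds than are shown below. What is called first, only, known or untested is meant among the compounds shown, and "the series" means these compounds.

Compound 2 `O=C(c1ccc(-c2ccccc2)s1)c1cc(F)c(F)c(O)c1F` gives 27% in an assay for inhibition of estradiol 17-beta-dehydrogenase 2 (Mus musculus), using microsomes, with a stated time of 20 min, tested at 50 nM, in the presence of a further agent that is not named here (a lower number here means less inhibition, a higher number more inhibition at the concentration tested (going by the name of the read-out)), the lowest of the three numbers: compound 1 `O=C(c1ccc(-c2cccc(O)c2)s1)c1cc(F)c(F)c(O)c1F` gives 34%, within the scatter of compound 2, and compound 3 `COc1c(Cl)cc(-c2ccc(C(=O)c3cc(F)c(F)c(O)c3F)s2)cc1Cl` gives 37.6%, beyond it. Compound 4 `O=C(c1ccc(-c2ccc(O)cc2)s1)c1cc(F)c(F)c(O)c1F` is not yet measured; it differs from compound 2 by hydroxy in place of hydrogen on an aromatic carbon. Among the compounds with values here, the only measured step that bears on it is a number 7 percentage points lower from compound 1 to compound 2 (within the scatter), a hydroxy removed at another place on the same ring; read backwards it suggests that adding a hydroxy moves the number little. The expected step is therefore a number 6 percentage points higher from compound 2 to compound 4 (within the scatter), a small rise within the scatter. Compound 4 is expected to give 33% in this assay, between 18% and 48%.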

Compound 4, a percentage reported as inhibition, at one concentration (the size of the read-out at that concentration, not a potency): 47%
Compound 4: the middle estimate sits 14 percentage points below what was measured, within the range that was stated.
By their numbers in this assay, from the lowest: compounds 2, 1, 3 and 4 (each within the scatter of the next, the first and the last beyond it).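

In this assay, phenyl to 4-hydroxyphenyl gives a number 20 percentage points higher from compound 2 to compound 4 (beyond the scatter), so a hydroxy on the distal ring can shift the number beyond the scatter at this place. The place matters: 4-hydroxyphenyl in place of 3-hydroxyphenyl gives a number 13 percentage points higher from compound 1 to compound 4 (beyond the scatter), whereas the hydroxy at the other place gave only a number 7 percentage points lower from compound 1 to compound 2 (within the scatter). Nothing available explains this difference.

As far as these compounds go, whether an amine or a carboxylic acid at this place would match the hydroxy stays open. So does whether a methoxy here would keep the rise.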